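Removing the large group from compound 3

The compounds below may be only part of what the source reports. "The series", "measured", "known", "first", "only" and "open" are said of these compounds alone.

In a functional assay for inhibition, with Homo sapiens as the target (on this read-out higher numbers stand for weaker inhibition and lower numbers for stronger inhibition), the measured compounds read as follows:
- compound 1 `O=C(NC[C@H](NS(=O)(=O)c1ccccc1)C(=O)O)c1cc2cc(OCC3CCNCC3)ccc2[nH]1`: 13 nM
- compound 2 `O=C(O)CCNC(=O)c1cc2cc(OCC3CCNCC3)ccc2[nH]1`: 1000 nM
- compound 3 `CC1(C)C2CCC1(Cc1ccc(S(=O)(=O)N[C@@H](CNC(=O)c3cc4cc(OCC5CCNCC5)ccc4[nH]3)C(=O)O)cc1)C(=O)C2`: 17 nM

Compound 3 stands with compound 1, their two values lying within the scatter of each other, while compound 2 has a far higher number than either. The change a hydrogen atom in place of a group of 10 heavy atoms (9 carbon, 1 oxygen; 2 five-membered non-aromatic rings of carbon only), on a saturated chain carbon bound to an aromatic carbon leads from compound 3 to compound 4 `Cc1ccc(S(=O)(=O)N[C@@H](CNC(=O)c2cc3cc(OCC4CCNCC4)ccc3[nH]2)C(=O)O)cc1`, which is still unmeasured.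

Within the data shown here, two measured steps bear on this change. The step of a 1.3-fold higher number from compound 1 to compound 3 (0.12 log units; within the scatter) comes closest, since it also concerns a large group on the aromatic end of the molecule, and it stays within the scatter. The step of a 77-fold higher number from compound 1 to compound 2 (1.89 log units; beyond the scatter) is large but removes the whole (phenylsulfonyl)amino, which compound 4 keeps, so it offers little guide here. No step beyond the scatter is therefore expected in this assay for this change. The estimated step is a 1.1-fold lower number from compound 3 to compound 4 (0.05 log units; within the scatter) and would be no more than scatter. The expected value for compound 4 is 15 nM with 6 nM to 40 nM as its estimated range.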

Compound 4, half-maximal inhibitory concentration: 6 nM
Compound 4: the middle estimate sits 2.5-fold (0.40 log units) above what was measured, and the stated range covers the measured number.
By their numbers in this assay, from the lowest: compound 4; then compounds 1 and 3 (each within the scatter of the next); then compound 2.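

In this assay methyl in place of hydrogen on an aromatic carbon gives a 2.2-fold lower number from compound 1 to compound 4 (0.34 log units; beyond the scatter) and a hydrogen atom in place of the group of 10 heavy atoms gives a 2.8-fold lower number from compound 3 to compound 4 (0.45 log units; beyond the scatter) as well; both steps are modest, so compound 4 has the lowest number of the set, a difference the within-scatter pair of compound 1 and compound 3 did not reveal. The step for ((4-methylphenyl)sulfonyl)amino in place of hydrogen, a 170-fold lower number from compound 2 to compound 4 (2.22 log units; beyond the scatter) is large and far exceeds these two. Nothing available accounts for these differences.

Open, from the compounds shown here alone, is whether ethyl, methoxy or a chlorine atom in place of the methyl on the aromatic carbon would lower the number further. Also open, going by these compounds, is how an amide or an ester in place of the carboxylic acid would read.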